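Amino for Carboxy on a Fused Bicyclic Fragment

The source may hold more compounds than are shown below. What is called first, only, known or untested is meant among the compounds shown, and "the series" means these compounds.

Of the compounds shown here, two have been measured in an assay on isolated protein for inhibition of tyrosine-protein kinase receptor UFO (Homo sapiens), with a stated time of 1.5 h; a lower number here means a stronger inhibitor, a higher number a weaker inhibitor. Compound 1, `Cc1ccc(C)n1-c1ccsc1C(=O)O`, gives 70000 nM in this assay. Compound 2, `O=C(O)c1ccc2c(Br)n[nH]c2c1`, does not reach a number at all: in this assay compound 2 is recorded only as > 770000 nM, which is a limit of the assay. Within the data shown here, the only evidence on where the measured values sit is the limit of > 770000 nM in this assay, at which 1 of the 2 values shown sits, so compound 2 stands at the weak end of the two results, with no finite value of its own.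

Compound 3, `Nc1ccc2c(Br)n[nH]c2c1`, is the next compound to be measured. It differs from compound 2 in one place: amino in place of carboxy on an aromatic carbon. Among the measured compounds shown here, no pair of measured compounds shows this same change, so the size of the step rests on judgment alone. The step from compound 2 to compound 3 is expected to be an at least 3.8-fold lower number from compound 2 to compound 3 (0.58 log units; beyond the scatter), toward stronger inhibition but with compound 3 still a weak inhibitor. Compound 3 is estimated at 200000 nM in this assay, within a range from 40000 nM to 770000 nM.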

Compound 3, half-maximal inhibitory concentration: > 770000 nM
Compound 3: a limit, no number; the forecaster's own chance of this, stated with the estimate: 40%; at least 3.8-fold (0.58 log units) between middle value and limit.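

In this assay compound 3 is recorded only as > 770000 nM, which is a limit of the assay and not a number. Compound 2 also carries only a limit, so no step can be read between compound 2 and compound 3. On these data alone, whether amino in place of carboxy on an aromatic carbon changes inhibition at all remains open.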